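Hydroxymethyl in Place of Sulfanyl: Expectation for Compound 4

The compounds below may be only part of what the source reports. "The series", "measured", "known", "first", "only" and "open" are said of these compounds alone.

Of the compounds shown here, three have been measured in a functional assay on the whole organism with Rattus norvegicus as the target; on this read-out higher numbers stand for an effect only at larger amounts of compound and lower numbers for an effect already at smaller amounts. Compound 1 `CCCCc1cc(O)cc(=O)n1Cc1ccc(-c2ccccc2-c2nn[nH]n2)cc1` gives 0.38 mg/kg, compound 2 `CCc1cc(O)cc(=O)n1Cc1ccc(-c2ccccc2-c2nn[nH]n2)cc1` gives 0.084 mg/kg, and compound 3 `CCCc1cc(S)cc(=O)n1Cc1ccc(-c2ccccc2-c2nn[nH]n2)cc1` gives 0.017 mg/kg, the lowest of the three numbers and beyond the scatter from both others. Among the measured compounds shown here, the only single-point step, a 4.5-fold lower number from compound 1 to compound 2 (0.66 log units; beyond the scatter), concerns the chain and does not bear on the exchange now considered. Compound 4 `CCCc1cc(CO)cc(=O)n1Cc1ccc(-c2ccccc2-c2nn[nH]n2)cc1` differs from compound 3 by hydroxymethyl in place of sulfanyl on an aromatic carbon. For the measured compounds named here, no measured pair isolates this exchange; compound 1 and compound 2 carry a hydroxy group and stand higher than compound 3, yet they also differ in the chain. Compound 4 is therefore expected to show a modest rise, a 4.7-fold higher number from compound 3 to compound 4 (0.67 log units; beyond the scatter), to an estimated 0.08 mg/kg in this assay, between 0.02 mg/kg and 0.4 mg/kg.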

Compound 4, dose for 50% inhibition: 0.3 mg/kg
Compound 4: middle estimate off by 3.8-fold (0.57 log units), on the low side, and the stated range covers the measured number.
By their numbers in this assay, from the lowest: compound 3; then compound 2; then compounds 4 and 1 (each within the scatter of the next).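

Among the compounds shown here, on this aromatic carbon, opposite the ring nitrogen, the exchange of sulfanyl for hydroxymethyl gives in this assay the first direct reading of the position: an 18-fold higher number from compound 3 to compound 4 (1.25 log units; beyond the scatter). The number therefore responds strongly to the group carried here, even though both groups hold 1 hydrogen-bond donor and 1 hydrogen-bond acceptor. No measurement at hand explains the size of this step.

From the compounds shown here alone, what an amine or a methyl group on this carbon would give remains open. So does whether the step would hold with a butyl chain in place of propyl.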